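The compounds below may be only part of what the source reports. "The series", "measured", "known", "first", "only" and "open" are said of these compounds alone.

Measured in an ADME assay on HEK293 cells (Homo sapiens) for inhibition, read by MTT assay, with stated times of 18 h and 4 h; on this read-out lower numbers stand for stronger inhibition and higher numbers for weaker inhibition:
Compound 1 `CCCCCCCCCCCCCCCCOP(=O)(O)OCCSC(=S)N1CCN(C)CC1`: > 100000 nM, a limit
Compound 2 `CCCCCCCCCCCCCCCCOP(=O)(O)OCCSC(=S)N1CCCCC1`: > 100000 nM, a limit

Compound 2 stands only at a limit, > 100000 nM, and has no exact number. Compound 3 `CCCCCCCCCCCCCCCCOP(=O)(O)OCCSC(=S)N1CCCC1` has pyrrolidin-1-yl in place of piperidin-1-yl on a thiocarbonyl carbon, so a six-membered non-aromatic ring gives way to a five-membered one: pyrrolidin-1-yl in place of piperidin-1-yl on a thiocarbonyl carbon. Among the measured compounds shown here, the one measured step that bears on this change sits on the same thiocarbonyl carbon, a step that the two limits leave unreadable from compound 1 to compound 2, and its size cannot be read. What the data do show is the limit of > 100000 nM in this assay, at which 2 of the 2 values shown sit. Neither measured compound gives a number, so no step beyond the usual scatter is expected in either direction, and compound 3 will probably also reach the limit in this assay. The expected change is a number no higher from compound 2 to compound 3 (the limit leaves the size open). For compound 3 the estimated value is 100000 nM, with an expected range of 40000 nM to 200000 nM.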

Compound 3, half-maximal inhibitory concentration: > 100000 nM
Compound 3 ended at the assay's limit (the forecaster's own chance of this, stated with the estimate: 80%); the middle value sits exactly at the limit.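

In this assay compound 3 gives > 100000 nM, a limit and not an exact number. As with compound 1 and compound 2, this leaves every step among the three compounds unreadable. The compounds shown leave open whether their different ring groups on the thiocarbonyl carbon change inhibition at all in this assay.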